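Dimethylamino for Acetyl on a Pyridine-Linked Phenyl Ring

The compounds below may be only part of what the source reports. "The series", "measured", "known", "first", "only" and "open" are said of these compounds alone.

In a functional assay on HCT-116 cells (Homo sapiens) for inhibition, read by sulforhodamine B assay, with a stated time of 48 h (a higher number here means a weaker inhibitor of growth, a lower number a stronger inhibitor of growth), compound 1 `COc1cc(C)cc(-c2c(-c3ccnc(-c4ccc(C(C)=O)cc4)c3)cnn2CC#N)c1` gives 5400 nM, the highest of the two numbers measured. Compound 2 `COc1cc(C)cc(-c2nn(CC#N)cc2-c2ccnc(-c3ccc(N(C)C)cc3)c2)c1`, which carries a dimethylamino group instead of the acetyl but on a differently arranged core, gives 1640 nM in this assay. Compound 3 `COc1cc(C)cc(-c2c(-c3ccnc(-c4ccc(N(C)C)cc4)c3)cnn2CC#N)c1` is compound 1 with dimethylamino in place of acetyl on an aromatic carbon. Among the compounds with values here, no measured pair shows exactly this step, but the value of compound 2 suggests the number should fall. The expected step from compound 1 to compound 3 is a 3.0-fold lower number from compound 1 to compound 3 (0.48 log units; beyond the scatter), a drop beyond the scatter, because compound 2 gives 1640 nM. Compound 3 is estimated at 1800 nM, between 600 nM and 5000 nM.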

Compound 3, concentration for total growth inhibition: 1030 nM
The estimate for compound 3 lay 1.7-fold (0.24 log units) above the measured number; low and high end bracket the measured number.
By their numbers in this assay, from the lowest: compounds 3 and 2 (each within the scatter of the next); then compound 1.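

Within the data shown here, with the core held fixed, dimethylamino in place of acetyl on this aromatic carbon, para to a large group, gives a 5.2-fold lower number from compound 1 to compound 3 (0.72 log units; beyond the scatter) in this assay, the first change here that can be read at this one place alone. The step lies beyond the usual scatter, which makes compound 3 the stronger inhibitor of growth of this pair. Nothing measured here accounts for the step. Still open, on these data alone, is how a primary amine, a morpholine or a carboxylic acid would read at this place. Also open, as far as these compounds go, is whether acetyl and dimethylamino differ in the same way on the core of compound 2.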